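Swapping isopropyl for phenyl on an aromatic carbon

The source may hold more compounds than are shown below. What is called first, only, known or untested is meant among the compounds shown, and "the series" means these compounds.

compound 1 `CCC(C)n1ncn(-c2ccc(N3CCN(c4ccc(OC[C@@H]5CO[C@@](CC6CCCC6)(c6ccc(Cl)cc6Cl)O5)cc4)CC3)cc2)c1=O` gives 512 nM
compound 2 `CCC(C)n1ncn(-c2ccc(N3CCN(c4ccc(OC[C@@H]5CO[C@@](Cc6ccccc6)(c6ccc(Cl)cc6Cl)O5)cc4)CC3)cc2)c1=O` gives 513 nM
compound 3 `CCC(C)n1ncn(-c2ccc(N3CCN(c4ccc(OC[C@@H]5CO[C@@](Cn6ccnc6C(C)C)(c6ccc(Cl)cc6Cl)O5)cc4)CC3)cc2)c1=O` gives 84 nM

These values come from a functional assay on HUVEC cells (Homo sapiens), read by scintillation counting and thymidine incorporation, with a stated time of 24 h (on this read-out higher numbers stand for weaker inhibition and lower numbers for stronger inhibition), and compound 3 has the lowest of the three numbers, so it is the strongest inhibitor so far. Compound 4 `CCC(C)n1ncn(-c2ccc(N3CCN(c4ccc(OC[C@@H]5CO[C@@](Cn6ccnc6-c6ccccc6)(c6ccc(Cl)cc6Cl)O5)cc4)CC3)cc2)c1=O` differs from compound 3 in one group: phenyl in place of isopropyl on an aromatic carbon. In words, this is phenyl in place of isopropyl on an aromatic carbon.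

For the measured compounds named here, no measured step changes this exact spot, so the evidence is indirect. Bringing in a phenyl group elsewhere gave a 1.0-fold higher number from compound 1 to compound 2 (0.00 log units; within the scatter), which shows no real change. Bringing in 2-isopropyl-1H-imidazol-1-yl gave two modest steps, a 6.1-fold lower number from compound 1 to compound 3 (0.78 log units; beyond the scatter) and a 6.1-fold lower number from compound 2 to compound 3 (0.79 log units; beyond the scatter). Compound 4 still carries a closely related group, 2-phenyl-1H-imidazol-1-yl, so most of that gain is expected to remain, although the data cannot show this directly. The expected step is a 1.2-fold higher number from compound 3 to compound 4 (0.08 log units; within the scatter), an estimate of a slight rise in the number that stays within the scatter. For compound 4 the estimated value is 100 nM, with an expected range from 40 nM to 260 nM.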

Compound 4, half-maximal inhibitory concentration: 136 nM
For compound 4 the middle estimate is 1.4-fold (0.13 log units) below the measured one; low and high end bracket the measured number.
By their numbers in this assay, from the lowest: compounds 3 and 4 (each within the scatter of the next); then compounds 1 and 2 (each within the scatter of the next).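

In this assay the swap of isopropyl for phenyl on this aromatic carbon between two ring nitrogen atoms gives a 1.6-fold higher number from compound 3 to compound 4 (0.21 log units; within the scatter) so the two groups cannot be told apart here, even though phenyl brings a six-membered aromatic ring where isopropyl has no ring. The advantage of the imidazole side chain therefore does not depend on isopropyl alone: the 2-phenyl-1H-imidazol-1-yl group still gives a 3.8-fold lower number from compound 2 to compound 4 (0.58 log units; beyond the scatter) and also a 3.8-fold lower number from compound 1 to compound 4 (0.58 log units; beyond the scatter) when set against the two side chains without an imidazole. No separate measurement is available to explain this tolerance.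

As far as these compounds go, whether a methyl group or an amine on the same carbon would fit equally well stays open. So does whether a plain imidazol-1-yl group, with nothing on that carbon, would keep the gain.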